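Swapping cyclopropyl for 4-fluorophenyl: expected oral exposure

The compounds below may be only part of what the source reports. "The series", "measured", "known", "first", "only" and "open" are said of these compounds alone.

Measured so far:
- compound 1 `C[C@H](Nc1nc(N)nc(N)c1C#N)c1cc2ccc(F)cn2c(=O)c1-c1ccccc1`: 1450 ng.h/mL
- compound 2 `Cc1c([C@H](C)Nc2nc(N)nc(N)c2C#N)c(-c2ccccc2)c(=O)n2cc(F)ccc12`: 1030 ng.h/mL
- compound 3 `C[C@H](Nc1nc(N)nc(N)c1C#N)c1c(-c2ccccc2)c(=O)n2cc(F)ccc2c1C1CC1`: 1090 ng.h/mL

In an ADME assay on the whole organism (Mus musculus, strain BALB/C), read by LC-MS, with a stated time of 24 h, at a dose of 10 mg/kg by the oral route (a higher number here means more compound in the circulation at the dose given, a lower number less compound in the circulation), compound 3 stands second highest of the three numbers, though the steps of a 1.1-fold higher number from compound 2 to compound 3 (0.02 log units; within the scatter) and a 1.3-fold lower number from compound 1 to compound 3 (0.12 log units; within the scatter) both lie within the scatter. Compound 4 `C[C@H](Nc1nc(N)nc(N)c1C#N)c1c(-c2ccccc2)c(=O)n2cc(F)ccc2c1-c1ccc(F)cc1` differs from compound 3 by 4-fluorophenyl in place of cyclopropyl on an aromatic carbon. The measured steps that bear on this site, a 1.4-fold lower number from compound 1 to compound 2 (0.15 log units; within the scatter) and a 1.3-fold lower number from compound 1 to compound 3 (0.12 log units; within the scatter), both left the number essentially unchanged. Within the data shown here, no measured step swaps in a group as large as 4-fluorophenyl, so the expectation rests on weaker ground; still, on these data the estimated step of a 1.2-fold lower number from compound 3 to compound 4 (0.08 log units; within the scatter) is expected to stay within the scatter, and compound 4 is estimated at 900 ng.h/mL with a range of 300 ng.h/mL to 2700 ng.h/mL.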

Compound 4, area under the concentration-time curve: 11200 ng.h/mL
For compound 4 the middle estimate is 12-fold (1.09 log units) below the measured one, outside the stated range (above it).
By their numbers in this assay, from the lowest: compounds 2, 3 and 1 (each within the scatter of the next); then compound 4.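

At this aromatic carbon, hydrogen, methyl and cyclopropyl give numbers within the scatter of one another in this assay, but 4-fluorophenyl stands clearly apart from all three: against cyclopropyl (a 10-fold higher number from compound 3 to compound 4 (1.01 log units; beyond the scatter)), against methyl (an 11-fold higher number from compound 2 to compound 4 (1.04 log units; beyond the scatter)) and against hydrogen (a 7.7-fold higher number from compound 1 to compound 4 (0.89 log units; beyond the scatter)). The position therefore does not tolerate every change equally, as the first three compounds alone suggested; a single swap here can change exposure sharply. Going by these compounds, whether plain phenyl or an amine at this carbon would give a similar number remains open. Nothing shown here explains the rise.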